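This account rests on a few compounds, and the source may have more. Where it says the series, first, only, none or still open, it means among the compounds named here.

Measured so far:
- compound 1 `CN(Cc1ccc(F)cc1)c1cc(C(=O)Nc2ccccc2)ncn1`: < 5000 nM (a limit)
- compound 2 `CN(Cc1ccc(C(F)(F)F)cc1)c1cc(C(=O)Nc2ccccc2)ncn1`: < 5000 nM (a limit)
- compound 3 `CN(Cc1ccc(S(C)(=O)=O)cc1)c1cc(C(=O)Nc2ccccc2)ncn1`: 10000 nM

In a physicochemical assay for solubility, using the shake flask method, measured as kinetic solubility, with a stated time of 2 h, at pH 7.4 (a higher number here means a more soluble compound, a lower number a less soluble compound), compound 1 gives < 5000 nM, which is a limit of the assay and not a number. Compound 1 therefore stands at the limit of < 5000 nM in this assay, at which 2 of the 3 values shown sit.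

Compound 4 `CN1CCN(c2cccc(NC(=O)c3cc(N(C)Cc4ccc(F)cc4)ncn3)c2)CC1` differs from compound 1 by one change: 4-methylpiperazin-1-yl in place of hydrogen on an aromatic carbon.

For the measured compounds named here, no measured step touches this hydrogen. The measured steps replace the fluoro group instead, so they are only a loose guide. One of them cannot be read: a step that the two limits leave unreadable from compound 1 to compound 2. The other is the only upward signal, and it comes with compound 3: an at least 2.0-fold higher number from compound 1 to compound 3 (0.30 log units; that floor lies within the scatter). Going by that step, a higher number is expected, with wide uncertainty.

The expected step is an at least 4.0-fold higher number from compound 1 to compound 4 (0.60 log units; beyond the scatter). The estimate for compound 4 is 20000 nM, with an expected range of 5000 nM to 80000 nM.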

Compound 4, solubility: 74000 nM
Compound 4: middle estimate off by 3.7-fold (0.57 log units), on the low side, and the stated range covers the measured number.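

In this assay, putting 4-methylpiperazin-1-yl on this aromatic carbon gives an at least 14-fold higher number from compound 1 to compound 4 (1.17 log units; beyond the scatter). For the compounds shown here, the earlier compounds changed only the fluoro group, so this is the first sign that the hydrogen position can also move the number, and by a large step. Compound 1 is known only as a limit, so this step is a floor: the limit of < 5000 nM in this assay, at which 2 of the 4 values shown sit.

Going by these compounds, whether a smaller amine such as dimethylamino, or a carboxylic acid, would do the same on this carbon stays open. So does whether 4-methylpiperazin-1-yl would give a similar step at another carbon of this ring.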